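Working notes: from 4-bromophenyl to 4-fluorophenyl

The compounds below may be only part of what the source reports. "The series", "measured", "known", "first", "only" and "open" are said of these compounds alone.

Compound 1 `Cc1nc(CS(=O)(=O)c2ccc(F)cc2)c([N+](=O)[O-])n1C` gives > 797000 nM (a limit)
Compound 2 `Cc1nc(CS(=O)(=O)c2ccc(Br)cc2)c([N+](=O)[O-])n1CCO` gives 124000 nM (a number)

Within the data shown here, in an ADME assay on THP-1 cells (Homo sapiens) for cytotoxicity, read by flow cytometry and propidium iodide staining, with a stated time of 72 h (on this read-out higher numbers stand for weaker inhibition and lower numbers for stronger inhibition), compound 2 gives 124000 nM, the only number so far. Compound 3 `Cc1nc(CS(=O)(=O)c2ccc(F)cc2)c([N+](=O)[O-])n1CCO` has fluoro in place of bromo on an aromatic carbon, para to a large group (fluoro in place of bromo on an aromatic carbon). Among the measured compounds shown here, no measured step covers this change. Compound 1 also carries 4-fluorophenyl, and its > 797000 nM is a limit. A modest step towards weaker inhibition is therefore expected in this assay, estimated as a 2.4-fold higher number from compound 2 to compound 3 (0.38 log units; beyond the scatter). Compound 3 is expected at 300000 nM, within an estimated range of 120000 nM to 750000 nM.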

Compound 3, half-maximal inhibitory concentration: > 728000 nM
Compound 3: a limit, no number; the forecaster's own chance of this, stated with the estimate: 30%; middle value at least 2.4-fold (0.38 log units) away from the limit.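

In this assay, among these compounds, fluoro in place of bromo on the aromatic carbon, with the rest of the structure unchanged, gives an at least 5.8-fold higher number from compound 2 to compound 3 (0.76 log units; beyond the scatter), the first readable step and one that shows this position affects the read-out. Compound 3 stands at a limit, not a number: the limit of > 728000 nM in this assay, at which 1 of the 3 values shown sits. The step involving compounds 1 and 3 cannot be read, as both values are limits.

As far as these compounds go, the full size of the step remains open. So does whether chloro or methoxy at this position would read closer to compound 2 or compound 3.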